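Carrying the Benzodioxin Amide onto Compound 3

The source may report more compounds than this note shows. Statements on the series, on what has been measured and on what is new or still open speak of the compounds shown alone.

Measured compounds:
compound 1, `O=C(NC(=S)Nc1cccc(-c2nc3ccccc3[nH]2)c1)c1ccccc1` — in a functional assay on MDA-MB-231 cells (Homo sapiens) for cytotoxicity, read by WST assay, with a stated time of 48 h (on this read-out lower numbers stand for stronger inhibition and higher numbers for weaker inhibition), compound 1 gives > 10000 nM, a limit of the assay
compound 2, `O=C(NC(=S)Nc1cccc(-c2nc3ccccc3[nH]2)c1)c1ccc2c(c1)OCCO2` — in this assay compound 2 gives 400 nM
compound 3, `Cc1ccc(-c2nc3ccccc3[nH]2)cc1NC(=S)NC(=O)c1ccccc1` — in this assay compound 3 gives > 10000 nM, a limit of the assay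

Compound 3 therefore stands at the limit of > 10000 nM in this assay, at which 2 of the 3 values shown sit, with only a limit and no number to its name. The step that the two limits leave unreadable from compound 1 to compound 3 is unreadable: both of its ends are limits. Going by the values given here, the one readable step in the set is an at least 25-fold lower number from compound 1 to compound 2 (1.39 log units; beyond the scatter), and that same exchange is now applied to compound 3 to give compound 4, `Cc1ccc(-c2nc3ccccc3[nH]2)cc1NC(=S)NC(=O)c1ccc2c(c1)OCCO2`: 2,3-dihydro-1,4-benzodioxin-6-yl in place of phenyl on a carbonyl carbon. The large drop recorded in an at least 25-fold lower number from compound 1 to compound 2 (1.39 log units; beyond the scatter) is the whole basis for what follows. A step of similar kind, toward stronger inhibition, is expected in this assay for compound 4, estimated as an at least 16-fold lower number from compound 3 to compound 4 (1.22 log units; beyond the scatter). Going by these compounds, since compound 3 reached only a limit, the true size of that drop remains open, and a wide range is appropriate. The estimate for compound 4 in this assay is 600 nM, expected to fall between 150 nM and 5000 nM.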

Compound 4, half-maximal inhibitory concentration: 530 nM
Estimate against measurement, compound 4: 1.1-fold (0.05 log units) above; measured number inside the range.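

In this assay, the exchange of phenyl for 2,3-dihydro-1,4-benzodioxin-6-yl on a carbonyl carbon now appears on a second core, as an at least 18-fold lower number from compound 3 to compound 4 (1.27 log units; beyond the scatter), so the large step is not confined to the core of compound 1. The methyl in place of hydrogen on an aromatic carbon also gets its first readable step, a 1.3-fold higher number from compound 2 to compound 4 (0.12 log units; within the scatter), which means that, with the 2,3-dihydro-1,4-benzodioxin-6-yl group present, the methyl leaves the number within the usual scatter. The two exchanges point the same way, but their sizes cannot be ranked: the same change on two cores in this assay, an at least 25-fold lower number (1.39 log units; beyond the scatter) from compound 1 to compound 2 and an at least 18-fold lower number (1.27 log units; beyond the scatter) from compound 3 to compound 4; the limit leaves it open whether they differ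

With phenyl on the carbonyl carbon, the step for the methyl cannot be read, as both of its ends are limits of the assay: the limit of > 10000 nM in this assay, at which 2 of the 4 values shown sit. The compounds shown also leave open whether a methoxy group or a carboxylic acid on the phenyl ring could do what the 2,3-dihydro-1,4-benzodioxin-6-yl group does in this assay, and whether an ethyl group or a chlorine atom in place of the methyl would stay as close to compound 2.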